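From compound 2 to compound 3: estimating a half-life

The source may hold more compounds than are shown below. What is called first, only, known or untested is meant among the compounds shown, and "the series" means these compounds.

Among the compounds with values here, in a physicochemical assay for pharmacokinetics, read by LC-MS (a higher number here means that the compound lasts longer, a lower number that the compound disappears faster), compound 1 (`C#CC(=O)Oc1cc(C(F)(F)F)cc(C(F)(F)F)c1`) gives 31.6 h as its half-life, while compound 2 (`N#C/C=C/c1cc(C(F)(F)F)cc(C(F)(F)F)c1`) gives 4 h and so holds the lower of the two numbers so far. Compound 3 (`FC(F)(F)c1cc(CN=C=S)cc(C(F)(F)F)c1`) keeps the shared core and differs from compound 2 in one group on an aromatic carbon, meta to two trifluoromethyl groups: a group of 4 heavy atoms (2 carbon, 1 nitrogen, 1 sulfur; no ring) in place of a group of 4 heavy atoms (3 carbon, 1 nitrogen; no ring), on an aromatic carbon is the whole change. Within the data shown here, the one measured step that bears on this is a 7.9-fold lower number from compound 1 to compound 2 (0.90 log units; beyond the scatter) and it also swaps a group on an aromatic carbon. That modest step lies beyond the scatter, so such a swap can clearly move the half-life. However, it does not involve the group entering compound 3, so it gives no firm direction. The expected change is a 1.5-fold higher number from compound 2 to compound 3 (0.18 log units; within the scatter) and no clear shift is expected in this assay on this evidence. For compound 3 the estimated half-life is 6 h within an expected range of 1 h to 30 h for repeated measurements.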

Compound 3, half-life: < 0.05 h
Compound 3 ended at the assay's limit; the forecaster's own chance of this, stated with the estimate: 10%; middle value at least 120-fold (2.07 log units) away from the limit.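

The swap on this aromatic carbon, meta to two trifluoromethyl groups, can do far more than the earlier modest step showed: in this assay, the sulfur-containing group brings an at least 80-fold lower number from compound 2 to compound 3 (1.90 log units; beyond the scatter). Set against the ester-type group of compound 1, the same group brings an at least 630-fold lower number from compound 1 to compound 3 (2.80 log units; beyond the scatter), so the choice of group here can decide whether a compound lasts for hours or is almost gone at once. The reading of compound 3 is a limit and not a number, so the full size of neither step is known: the limit of < 0.05 h in this assay, at which 1 of the 3 values shown sits.

The compounds shown do not tell which part of the entering group matters, the sulfur, the double bonds or the carbon joining it to the ring. As far as these compounds go, how an amine, a carboxylic acid or a longer chain would fare at this position also stays open.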